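Swapping the Amide Amine in a Nitro Sulfone Series

The source may report more compounds than this note shows. Statements on the series, on what has been measured and on what is new or still open speak of the compounds shown alone.

Three amides were examined in an assay on isolated protein for inhibition of vitamin D3 receptor (Homo sapiens), read by fluorescence polarization; on this read-out lower numbers stand for stronger inhibition and higher numbers for weaker inhibition. For compound 1 `CC1CCN(C(=O)CN(C)C(=O)c2ccc(S(C)(=O)=O)c([N+](=O)[O-])c2)CC1` the read-out is only a limit of the assay, > 60000 nM. For compound 2 `CS(=O)(=O)c1ccc(C(=O)NCC(=O)N(Cc2ccccc2)Cc2ccccc2)cc1[N+](=O)[O-]` the read-out is likewise a limit, > 60000 nM. Compound 3 `CC(C)N(C(=O)CCNC(=O)c1ccc(S(C)(=O)=O)c([N+](=O)[O-])c1)C(C)C` also gives only a limit, > 60000 nM. Compound 3 thus stands at the same limit as the other two, which is the limit of > 60000 nM in this assay, at which 3 of the 3 values shown sit. Compound 4 `CC1CCN(C(=O)CCNC(=O)c2ccc(S(C)(=O)=O)c([N+](=O)[O-])c2)CC1` differs from compound 3 at one place: 4-methylpiperidin-1-yl in place of diisopropylamino on a carbonyl carbon. The group that enters is already present in compound 1, which also sits at the limit. No step beyond the scatter is expected, and compound 4 is estimated to stay at the limit, with an expected step that the limit leaves unreadable from compound 3 to compound 4. The estimate for compound 4 is 80000 nM, ranging from 30000 nM to 300000 nM.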

Compound 4, half-maximal inhibitory concentration: > 60000 nM
Compound 4 gave a limit, no number; the forecaster's own chance of this, stated with the estimate: 85%; the middle value lies beyond the limit too.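

Compound 3 and compound 4 both gave only limits, so no step can be read between them. The compounds shown leave open whether any amide of the shared core gives a readable value: the limit of > 60000 nM in this assay, at which 4 of the 4 values shown sit.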